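This account rests on a few compounds, and the source may have more. Where it says the series, first, only, none or still open, it means among the compounds named here.

Three compounds have values so far in a functional assay on U-251 cells (Homo sapiens) for inhibition, read by MTT assay, with a stated time of 2 days (a higher number here means a weaker inhibitor of growth, a lower number a stronger inhibitor of growth), as follows:

- compound 1 `Nc1ccccc1NC(=O)CCCNCC(=O)Nc1cccc(Cl)c1` gives 19500 nM
- compound 2 `Nc1ccccc1NC(=O)CCCNCC(=O)Nc1ccc(Cl)cc1` gives 11400 nM
- compound 3 `Nc1ccccc1NC(=O)CCCNCC(=O)Nc1ccccc1Cl` gives 28600 nM

Compound 1 holds the middle number of these three, but it is not clearly separated from either of the others. Its two steps are a 1.7-fold lower number from compound 1 to compound 2 (0.23 log units; within the scatter) and a 1.5-fold higher number from compound 1 to compound 3 (0.17 log units; within the scatter) in this comparison. Going by the values given here, only one step among the three goes beyond the scatter, and it is modest: a 2.5-fold higher number from compound 2 to compound 3 (0.40 log units; beyond the scatter) here.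

Compound 4 `COc1ccc(NC(=O)CNCCCC(=O)Nc2ccccc2N)cc1` has not yet been measured. It keeps the core of compound 1 but carries 4-methoxyphenyl in place of 3-chlorophenyl on an amide-type nitrogen, a change counted as 4-methoxyphenyl in place of 3-chlorophenyl on an amide-type nitrogen in full.

Among the compounds with values here, no measured compound carries a methoxy group, so the evidence is indirect. The closest guide is the 4-chlorophenyl of compound 2, whose group name matches most nearly, and the step of a 1.7-fold lower number from compound 1 to compound 2 (0.23 log units; within the scatter) stayed small. A large change is therefore not expected in this assay and, at most, a slightly lower number seems likely. The expected change is a 1.4-fold lower number from compound 1 to compound 4 (0.14 log units; within the scatter) and would not go beyond the scatter. For compound 4 the estimated value is 14000 nM with an expected range from 6000 nM to 30000 nM when measured.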

Compound 4, concentration for 50% growth inhibition: 34000 nM
Beside the measured number, compound 4's estimate is 2.4-fold (0.39 log units) below it, and the stated range ends below it.
By their numbers in this assay, from the lowest: compounds 2, 1, 3 and 4 (each within the scatter of the next, the first and the last beyond it).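

In this assay, compounds 1 to 3 differ only in where the chlorine sits, whereas compound 4 changes the group itself, and methoxy in place of chloro on an aromatic carbon gives a 3.0-fold higher number from compound 2 to compound 4 (0.47 log units; beyond the scatter) as a modest step beyond the scatter. The other two comparisons, a 1.7-fold higher number from compound 1 to compound 4 (0.24 log units; within the scatter) and a 1.2-fold higher number from compound 3 to compound 4 (0.08 log units; within the scatter) in the same assay, stay within the scatter, so 4-methoxyphenyl on the amide-type nitrogen cannot be told apart from 3-chlorophenyl or 2-chlorophenyl there. The separation is therefore specific to the pairing with 4-chlorophenyl, although compound 2 itself remains within the scatter of compound 1, and no accompanying measurement offers an explanation for this difference between methoxy and chloro.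

Going by these compounds, it remains open how 3-methoxyphenyl and 2-methoxyphenyl would compare with the matching chlorophenyl compounds, which would show whether the methoxy result holds elsewhere on the ring. Also open, on these data alone, is how an unsubstituted phenyl, or a phenyl ring carrying an amine or a carboxylic acid in place of chloro, would read on the same amide-type nitrogen.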